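This account rests on a few compounds, and the source may have more. Where it says the series, first, only, none or still open, it means among the compounds named here.

Compound 2 `COc1ccc(-n2nc(C(=O)Nc3ccc(Oc4ccnc5cc(OCCCN6CCCC6)c(OC)cc45)c(F)c3)c(C)cc2=O)cc1` stands at the higher of the two numbers seen so far: in a functional assay on MKN-45 cells (Homo sapiens) for inhibition, read by MTT assay, with a stated time of 72 h (on this read-out higher numbers stand for weaker inhibition and lower numbers for stronger inhibition), compound 2 gives 1290 nM, while compound 1 `COc1cc2c(Oc3ccc(NC(=O)c4nn(-c5cccc(F)c5)c(=O)cc4C)cc3F)ccnc2cc1OCCCN1CCCC1` gives 120 nM. Among the measured compounds shown here, the one measured step, an 11-fold higher number from compound 1 to compound 2 (1.03 log units; beyond the scatter), changed the same aryl group on the ring nitrogen. Compound 3 `COc1cc2c(Oc3ccc(NC(=O)c4nn(-c5ccc(Cl)cc5)c(=O)cc4C)cc3F)ccnc2cc1OCCCN1CCCC1` differs from compound 2 by chloro in place of methoxy on an aromatic carbon. For the measured compounds named here, no measured step matches this exchange, so the expectation rests only on that one step, which showed the aryl substituent matters greatly; compound 3 is therefore estimated to move toward compound 1 by a 3.2-fold lower number from compound 2 to compound 3 (0.51 log units; beyond the scatter), giving an expected 400 nM within 120 nM to 1500 nM.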

Compound 3, half-maximal inhibitory concentration: 150 nM
The estimate for compound 3 lay 2.7-fold (0.43 log units) above the measured number; the measured number falls inside the stated range.
By their numbers in this assay, from the lowest: compounds 1 and 3 (each within the scatter of the next); then compound 2.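

Moving from methoxy to chloro on this carbon, para to a large group, gives an 8.6-fold lower number from compound 2 to compound 3 (0.93 log units; beyond the scatter) in this assay, so the weak result of compound 2 does not come from any group at this place. The step of a 1.3-fold higher number from compound 1 to compound 3 (0.10 log units; within the scatter) shows that 4-chlorophenyl and 3-fluorophenyl on the aromatic nitrogen cannot be told apart here, and of the three aryl groups shown only 4-methoxyphenyl stands apart. No measurement shown here explains the gap between methoxy and chloro. On these data alone, it remains open whether an amine, a carboxylic acid or a longer alkoxy chain at this place would read like methoxy or like chloro.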